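The compounds below may be only part of what the source reports. "The series", "measured", "known", "first", "only" and "open" are said of these compounds alone.

Measured compounds:
- compound 1 `O=C(NCCCNc1nc(Nc2cnn(C3CC3)c2)ncc1C1CC1)C1CCC1`, in an assay on isolated protein for inhibition of serine/threonine-protein kinase TBK1 (Homo sapiens) (a lower number here means a stronger inhibitor, a higher number a weaker inhibitor), compound 1 gives 10 nM
- compound 2 `CN(C)Cc1ccc(Nc2ncc(C3CC3)c(NCCCNC(=O)C3CCC3)n2)cc1`, in this assay compound 2 gives 6 nM

Within the data shown here, compound 2 has the lowest of the two numbers so far, but its only neighbour is compound 1, and the step of a 1.7-fold lower number from compound 1 to compound 2 (0.22 log units; within the scatter) is within the scatter, so the two are not separated. Compound 3 `Cn1ccc(Nc2ncc(C3CC3)c(NCCCNC(=O)C3CCC3)n2)n1` is not yet measured. It differs from compound 2 in one place: 1-methyl-1H-pyrazol-3-yl in place of 4-((dimethylamino)methyl)phenyl on a nitrogen on an aromatic ring. Among the measured compounds shown here, the one measured step that bears on this is a 1.7-fold lower number from compound 1 to compound 2 (0.22 log units; within the scatter), which exchanged a pyrazolyl group for the 4-((dimethylamino)methyl)phenyl group at the same nitrogen and moved the number only within the scatter. Returning to a pyrazolyl group, now the 1-methyl-1H-pyrazol-3-yl, is therefore expected to give a step of about a 2.0-fold higher number from compound 2 to compound 3 (0.30 log units; within the scatter) in this assay, that is, no change beyond the scatter. For compound 3 the expected value in this assay is 12 nM, with a range from 4 nM to 40 nM.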

Compound 3, half-maximal inhibitory concentration: > 1000 nM
Compound 3: a limit, no number; the forecaster's own chance of this, stated with the estimate: 2%; middle value at least 83-fold (1.92 log units) away from the limit.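

In this assay the group on this nitrogen cannot be exchanged freely, even though the first change there stayed within the scatter. Having a pyrazolyl group there is also not enough: 1-methyl-1H-pyrazol-3-yl gives an at least 100-fold higher number from compound 1 to compound 3 (2.00 log units; beyond the scatter) and also an at least 160-fold higher number from compound 2 to compound 3 (2.22 log units; beyond the scatter), so compound 1 and compound 3 fall far apart although both carry a pyrazolyl group. From the compounds shown here alone, the true size of this loss is unknown, since compound 3 reads only as a limit of the assay, not a number: the limit of > 1000 nM in this assay, at which 1 of the 3 values shown sits.

The compounds shown leave open whether the loss follows the ring's point of attachment or the methyl in place of the cyclopropyl. A 1-methyl-1H-pyrazol-4-yl group on the same nitrogen would separate these two changes.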